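Halogen Swap on a Fused Ring: Bromo to Fluoro

The compounds below may be only part of what the source reports. "The series", "measured", "known", "first", "only" and "open" are said of these compounds alone.

Compound 1, `Cc1cc(F)ccc1C1=Nc2c(Cl)cccc2SC(C(=O)O)C1`: > 10000000 nM in a functional assay on HL-60 cells (Homo sapiens), read by MTT assay, with a stated time of 72 h; on this read-out lower numbers stand for stronger inhibition of growth and higher numbers for weaker inhibition of growth
Compound 2, `Cc1cc(F)ccc1C1=Nc2c(Br)cccc2SC(C(=O)O)C1`: 2500000 nM in this assay
Compound 3, `Cc1ccc2c(c1)SC(C(=O)O)CC(c1ccc(F)cc1C)=N2`: > 10000000 nM in this assay

Compound 2 is the only one of the three that gives a number in this assay. For compound 1 the value is a limit of the assay, not a number. For compound 3 the value is likewise a limit of the assay. Two of the three values thus sit at the limit of > 10000000 nM in this assay, at which 2 of the 3 values shown sit.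

Within the data shown here, the one measured step, an at least 4.0-fold lower number from compound 1 to compound 2 (0.60 log units; beyond the scatter), shows that exchanging one halogen for another at this position can move the number beyond the scatter. Compound 4, `Cc1cc(F)ccc1C1=Nc2c(F)cccc2SC(C(=O)O)C1`, carries a further halogen exchange at the same place: fluoro in place of bromo on an aromatic carbon. Since replacing bromo by chloro in compound 1 only brought the number to a limit, another change in the same direction is expected to raise the number again rather than lower it. Compound 4 is therefore estimated at 10000000 nM, in a range from 2500000 nM to 40000000 nM, most likely again reported as a limit. This expected step is a 4.0-fold higher number from compound 2 to compound 4 (0.60 log units; beyond the scatter).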

Compound 4, concentration for 50% growth inhibition: 6600000 nM
Compound 4: the middle estimate sits 1.5-fold (0.18 log units) above what was measured; the measured number falls inside the stated range.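

Compound 4 gives a true number, so two halogens can now be compared directly at this aromatic carbon, and in this assay the exchange of bromo for fluoro produces a 2.6-fold higher number from compound 2 to compound 4 (0.42 log units; beyond the scatter) and leaves bromo the better of the two. The value of compound 1 is a limit of the assay and not a number. Measured against that limit, the change of chloro to fluoro reads as an at least 1.5-fold lower number from compound 1 to compound 4 (0.18 log units; that floor lies within the scatter) and so does not put these two halogens in any order.

The compounds shown leave open whether a group other than a halogen at this carbon, such as an amine, a methoxy group or a nitrile, would bring the number lower. They also leave open how iodo behaves at this place, and whether the gap between bromo and fluoro would survive if the carboxylic acid of the shared core gave way to an amide.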